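This account rests on a few compounds, and the source may have more. Where it says the series, first, only, none or still open, it means among the compounds named here.

Measured compounds:

- compound 1, `C#CCSc1nc(Nc2cccc(Cl)c2)c(C#N)c(-c2ccccc2)n1` — 10500 nM
- compound 2, `Cc1cccc(Nc2nc(SCc3cn(Cc4ccccc4Cl)nn3)nc(-c3ccccc3)c2C#N)c1` — 13500 nM
- compound 3, `Cc1ccc(Cn2cc(CSc3nc(Nc4ccccc4Cl)c(C#N)c(-c4ccccc4)n3)nn2)cc1` — 7080 nM

All three numbers come from a functional assay on B16-F10 cells (Mus musculus) for inhibition, read by MTT assay, with a stated time of 72 h; on this read-out higher numbers stand for weaker inhibition and lower numbers for stronger inhibition. Compound 1 gives 10500 nM in this assay, compound 2 gives 13500 nM and compound 3 gives 7080 nM. Compound 2 holds the largest of the three numbers, but its gap to compound 1 and its gap to compound 3 both fall within the scatter, so nothing separates the three compounds on these data. Going by the values given here, no pair among them differs in a single place, so no single-point step is available from the measured set.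

Compound 4, `Cc1ccc(Nc2nc(SCc3cn(Cc4ccccc4Cl)nn3)nc(-c3ccccc3)c2C#N)cc1`, is not yet measured. It is built from the same atoms as compound 2, joined differently: 4-methylphenyl in place of 3-methylphenyl on a nitrogen on an aromatic ring. The change is confined to the 4-methylphenyl in place of 3-methylphenyl on a nitrogen on an aromatic ring; the rest of the structure is unchanged.

With no measured step of this kind in the series, the expectation for the move from compound 2 to compound 4 is no change beyond the scatter, in either direction, so a 1.1-fold lower number from compound 2 to compound 4 (0.05 log units; within the scatter) is the step expected. On that basis compound 4 is estimated at 12000 nM in this assay, with a range from 5000 nM to 30000 nM.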

Compound 4, half-maximal inhibitory concentration: 3390 nM
Compound 4: middle estimate off by 3.5-fold (0.55 log units), on the high side, and the stated range ends above it.
By their numbers in this assay, from the lowest: compound 4; then compounds 3, 1 and 2 (each within the scatter of the next).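

In this assay, going by these compounds alone, the exchange of 3-methylphenyl for 4-methylphenyl on a nitrogen on an aromatic ring gives a 4.0-fold lower number from compound 2 to compound 4 (0.60 log units; beyond the scatter) and provides the first single-place step. Compound 2 and compound 4 contain the same atoms, and the leaving and entering groups match in heavy atoms, ring type, hydrogen-bond donors and acceptors, and net charge, so the listed difference is only in where the methyl stands on that ring; this position therefore does not tolerate the two placements equally in this cell read-out. No measurement here bears on the reason for the step.

A single pair cannot show whether the same step appears with the rest of the structure changed, for example with other substitution on the benzyl group attached to the triazole. It also leaves open how a plain phenyl, or an ethyl, methoxy or chlorine in place of the methyl of the 4-methylphenyl, would compare with compound 4.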